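From Isopropyl to Fluorobenzyl on a Potent Sulfonamide

This account rests on a few compounds, and the source may have more. Where it says the series, first, only, none or still open, it means among the compounds named here.

Compound 3 `Cc1cc(C)c(S(=O)(=O)N2CCC(N3CCC(C(C)C)CC3)CC2)c(C)c1` is the strongest of the measured compounds in a functional assay on DLD-1 cells (Homo sapiens) for antiproliferative activity, read by CellTiter-Glo, with a stated time of 72 h (a lower number here means a stronger inhibitor, a higher number a weaker inhibitor), where compound 3 gives 0.3 nM. Compound 2 `Cc1cc(C)c(S(=O)(=O)N2CCC(N3CCN(C)CC3)CC2)c(C)c1` gives 1100 nM in this assay. Compound 1 `Cc1cc(C)c(S(=O)(=O)N2CCC(C3OCC(C)CO3)CC2)c(C)c1` reaches only a limit of this assay, > 5000 nM. Replacing 4-methylpiperazin-1-yl with 4-isopropylpiperidin-1-yl on a saturated ring carbon gave a 3700-fold lower number from compound 2 to compound 3 (3.56 log units; beyond the scatter); the other two measured steps were an at least 16000-fold lower number from compound 1 to compound 3 (4.22 log units; beyond the scatter) and an at least 4.5-fold lower number from compound 1 to compound 2 (0.65 log units; beyond the scatter).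

Compound 4 `Cc1cc(C)c(S(=O)(=O)N2CCC(N3CCC(Cc4ccccc4F)CC3)CC2)c(C)c1` keeps the core of compound 3 and alters only the group on the saturated ring carbon of the six-membered non-aromatic ring with 1 nitrogen: 2-fluorobenzyl in place of isopropyl on a saturated ring carbon. Within the data shown here, none of the measured steps touches this group; all three exchange the whole ring attached to the saturated ring carbon, so they speak only indirectly to this change. The expectation therefore rests mainly on how compound 3 stands, which already gives 0.3 nM. A number near it has little room to fall further, so a modest step is expected here: a 3.3-fold higher number from compound 3 to compound 4 (0.52 log units; beyond the scatter). Compound 4 is expected to give 1 nM, in a range from 0.1 nM to 10 nM.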

Compound 4, half-maximal inhibitory concentration: 74 nM
For compound 4 the middle estimate is 74-fold (1.87 log units) below the measured one; measured number outside the range, above it.
By their numbers in this assay, from the lowest: compound 3; then compound 4; then compound 2. At a limit, above all of these: compound 1.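

In this assay the change from isopropyl to 2-fluorobenzyl gave a 250-fold higher number from compound 3 to compound 4 (2.39 log units; beyond the scatter) and so shows that this saturated ring carbon is far from indifferent to what it carries, even with the ring around it left unchanged. The earlier steps shown here all exchanged the whole ring attached to the core, so they could not show that a change confined to this one group can move the number so far by itself, with neither the leaving nor the entering group holding a hydrogen-bond donor, a hydrogen-bond acceptor or a net charge. No measurement given here bears on why the number rose, so the step records a size and not a cause.

The compounds shown leave open whether the rise belongs to the benzyl part or to its fluorine, and plain benzyl on the same carbon would separate the two. Ethyl or cyclopropyl at this place would show how closely the group must resemble isopropyl to keep a number near that of compound 3 at 0.3 nM in this assay.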